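Demethylation on the Ring Amine Nitrogen Across Two Cores

The compounds below may be only part of what the source reports. "The series", "measured", "known", "first", "only" and "open" are said of these compounds alone.

Within the data shown here, compound 1 `CO[C@H]1CC=C2CCN(C)[C@H]2C1` is the only member of the set with a numerical value: in an assay on HEK293 cells for displacement of a labelled ligand from Neuronal acetylcholine receptor; alpha4/beta2 (Rattus norvegicus), with a stated time of 4 h (a higher number here means a weaker inhibitor, a lower number a stronger inhibitor), compound 1 gives 3400 nM. Compound 2 `CN1CC[C@@H]2CC[C@H](O)C[C@@H]21` is built on a different core, and how the two cores differ is not broken down here. In this assay compound 2 gives only a limit, > 300000 nM. Compound 3 `O[C@H]1CC[C@H]2CCN[C@H]2C1` differs from compound 2 by hydrogen in place of methyl on an amine nitrogen in a ring. In this assay compound 3 likewise gives a limit, > 300000 nM. The step that the two limits leave unreadable from compound 2 to compound 3 therefore has no readable size, owing to the limit of > 300000 nM in this assay, at which 2 of the 3 values shown sit. Compound 4 `CO[C@H]1CC=C2CCN[C@H]2C1` differs from compound 1 by hydrogen in place of methyl on an amine nitrogen in a ring. Among the measured compounds shown here, this is the same kind of change as the one from compound 2 to compound 3, not the same change, since around the place in compound 2 the nitrogen is additionally described as two ring bonds from the ring atom that bears a fused ring. For the measured compounds named here, because compound 1 gives 3400 nM and the only measured instance of the change is unreadable, compound 4 is expected to land near that value, estimated at 2000 nM with a range from 300 nM to 15000 nM. Relative to compound 1, compound 4 is thus expected to move by a 1.7-fold lower number from compound 1 to compound 4 (0.23 log units; within the scatter).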

Compound 4, inhibition constant: 300000 nM
Compound 4: the middle estimate sits 150-fold (2.18 log units) below what was measured, and the stated range ends below it.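

In this assay, among these compounds, hydrogen in place of methyl on an amine nitrogen in a ring gives an 88-fold higher number from compound 1 to compound 4 (1.95 log units; beyond the scatter) on the one core where the change can be sized. On the other core the same kind of change cannot be read, because compound 2 and compound 3 both stand at a limit: the limit of > 300000 nM in this assay, at which 2 of the 4 values shown sit. The series therefore shows a large step on a single core from a single pair of compounds, and it does not show whether that step carries over to the other core, or that it would hold as a rule for the series.

Open, going by these compounds, is how ethyl or a longer chain on that amine nitrogen would read on either core. Also open, on these data alone, is whether methoxy in place of the hydroxyl on the core of compound 2 would bring that core off the limit, which would make the change readable on a second core.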